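From a Chlorophenyl Urea to a Bromophenyl Urea

This account rests on a few compounds, and the source may have more. Where it says the series, first, only, none or still open, it means among the compounds named here.

Compound 1 `COc1cc(NC(C)CCCNC(=O)Nc2ccc(F)cc2)c2ncccc2c1` gives 26000 nM in a functional assay on NCI-H460 cells (Homo sapiens) for inhibition, read by MTT assay, with a stated time of 72 h; a lower number here means a stronger inhibitor, a higher number a weaker inhibitor.
Compound 2 `COc1cc(NC(C)CCCNC(=O)Nc2ccc(O)cc2)c2ncccc2c1` gives 34000 nM in this assay.
Compound 3 `COc1cc(NC(C)CCCNC(=O)Nc2cccc(Cl)c2)c2ncccc2c1` gives 37000 nM in this assay.

All three compounds share one core and differ only in the aromatic ring carried on the urea nitrogen. Compound 3 shows the highest number of the three, yet the steps of a 1.4-fold higher number from compound 1 to compound 3 (0.15 log units; within the scatter) and a 1.1-fold higher number from compound 2 to compound 3 (0.04 log units; within the scatter) both lie within the scatter, so the three compounds cannot be told apart on these numbers. The step to compound 4 `COc1cc(NC(C)CCCNC(=O)Nc2ccc(Br)cc2)c2ncccc2c1` is 4-bromophenyl in place of 3-chlorophenyl on an amide-type nitrogen. The measured step that bears most on this change is a 1.4-fold higher number from compound 1 to compound 3 (0.15 log units; within the scatter), which runs the other way, from a 4-fluorophenyl to a 3-chlorophenyl, and stayed within the scatter; the step of a 1.3-fold higher number from compound 1 to compound 2 (0.12 log units; within the scatter) also shows that swapping the group on that ring moved little. A step of no size beyond the scatter is therefore expected in this assay for compound 4, perhaps slightly toward compound 1. For compound 4 the estimated value is 30000 nM, with a range from 15000 nM to 60000 nM, meaning an expected step of a 1.2-fold lower number from compound 3 to compound 4 (0.09 log units; within the scatter).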

Compound 4, half-maximal inhibitory concentration: 30000 nM
The estimate for compound 4 equals the measured number at the digits printed; measured number inside the range.
By their numbers in this assay, from the lowest: compounds 1, 4, 2 and 3 (each within the scatter of the next).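

The bromo group on this ring leaves the number where it was: the step to 4-bromophenyl on the amide-type nitrogen gives a 1.2-fold lower number from compound 3 to compound 4 (0.09 log units; within the scatter) in this assay, even though the halogen and its place on the ring differ together. Bromo in place of the other two ring groups gives a 1.1-fold lower number from compound 2 to compound 4 (0.05 log units; within the scatter) and a 1.2-fold higher number from compound 1 to compound 4 (0.06 log units; within the scatter), so all four groups now tested on this ring fall within the scatter of one another in this assay. No measurement shown bears on why these steps stay so small.

Still open, as far as these compounds go, is whether an amine or a carboxylic acid on this ring would shift the number beyond the scatter. Also open, from the compounds shown here alone, is whether a longer chain between the shared core and the urea would do so.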